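Hydroxamate series: carbamate for benzyl at the side-chain amine

This account rests on a few compounds, and the source may have more. Where it says the series, first, only, none or still open, it means among the compounds named here.

Compound 1 `CC[C@@H](C)[C@@H](NC(=O)OCc1ccccc1)C(=O)NCC(NCc1ccccc1)C(=O)NO` gives 94 nM in an assay on isolated protein for inhibition of bone morphogenetic protein 1 (Homo sapiens) (on this read-out higher numbers stand for weaker inhibition and lower numbers for stronger inhibition), the second highest of the three numbers. Compound 3 `CC[C@H](C)[C@H](NS(=O)(=O)c1ccc(Br)c(Br)c1)C(=O)N[C@@H](CNC(=O)OCc1ccccc1)C(=O)NO` gives 26 nM, a lower number beyond the scatter, while compound 2 `CNC(=O)[C@H](CCC(N)=O)NC(=O)[C@H](CC(=O)O)CC(=O)NO` gives 68000 nM, far higher and also beyond the scatter. Compound 4 `CC[C@@H](C)[C@@H](NC(=O)OCc1ccccc1)C(=O)NCC(NC(=O)OCc1ccccc1)C(=O)NO` has not been measured in this assay. Its difference from compound 1 is benzyloxycarbonyl in place of benzyl on an amine nitrogen. Among the measured compounds shown here, no single-change step between measured compounds sizes this exchange; compound 3 carries a (benzyloxycarbonyl)amino group and gives 26 nM, but it differs from compound 1 in several further places, so it is only a loose pointer. A small step toward a lower number is expected, a 1.6-fold lower number from compound 1 to compound 4 (0.19 log units; within the scatter), possibly within the scatter. Compound 4 is estimated at 60 nM, range 20 nM to 200 nM.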

Compound 4, half-maximal inhibitory concentration: 61 nM
Estimate against measurement, compound 4: 1.0-fold (0.01 log units) below; the measured number falls inside the stated range.
By their numbers in this assay, from the lowest: compound 3; then compounds 4 and 1 (each within the scatter of the next); then compound 2.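

In this assay the exchange of benzyl for benzyloxycarbonyl on an amine nitrogen now has a measured size, a 1.5-fold lower number from compound 1 to compound 4 (0.19 log units; within the scatter), so on this read-out the two groups are not separated at this position. The carbonyl and the two hydrogen-bond acceptors that enter therefore bring no step beyond the scatter here. No measurement at hand gives a reason for this result.

On these data alone, whether a free amine or an acetyl group on this nitrogen would stay level with these two remains open. Also open, as far as these compounds go, is whether the exchange gives the same small step with a sulfonamide at the other end of the molecule.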